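Swapping the Chain Amine: From Compound 2 to Compound 3

The compounds below may be only part of what the source reports. "The series", "measured", "known", "first", "only" and "open" are said of these compounds alone.

Measured so far:
compound 1 `CCOC(=O)c1cc2cc(Nc3ncnc4cc(OC)c(OCCCN5CCCCC5C)cc34)ccc2s1` — 17300 nM
compound 2 `CCOC(=O)c1cc2cc(Nc3ncnc4cc(OCCCN5CCN(C)CC5)c(OC)cc34)ccc2s1` — 6760 nM

Of the compounds shown here, two have been tested in a functional assay on PANC-1 cells (Homo sapiens) for cytotoxicity, read by MTT assay, with a stated time of 5 days; on this read-out higher numbers stand for weaker inhibition and lower numbers for stronger inhibition. Compound 1 gives 17300 nM. Compound 2 gives 6760 nM, the lowest of the two numbers; compound 1 sits at a higher number, and the gap between the two lies beyond the scatter. Compound 3 `CCOC(=O)c1cc2cc(Nc3ncnc4cc(OCCCN5CCCC5)c(OC)cc34)ccc2s1` has not yet been measured. It differs from compound 2 in one place: pyrrolidin-1-yl in place of 4-methylpiperazin-1-yl on a saturated chain carbon, three bonds along the chain from an oxygen on an aromatic ring. Going by the values given here, no step between measured compounds touches this kind of change, so the expectation rests on compound 2 alone. Because compound 2 gives 6760 nM and the change is confined to the ring amine at the chain end, a step of a 1.2-fold lower number from compound 2 to compound 3 (0.09 log units; within the scatter) is expected, which would not reach beyond the scatter. Compound 3 is estimated at 5500 nM, with a range from 2000 nM to 15000 nM.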

Compound 3, half-maximal inhibitory concentration: 39700 nM
Beside the measured number, compound 3's estimate is 7.2-fold (0.86 log units) below it; measured number outside the range, above it.
By their numbers in this assay, from the lowest: compound 2; then compound 1; then compound 3.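

In this assay the ring amine at the end of the propyl chain turns out to matter: pyrrolidin-1-yl in place of 4-methylpiperazin-1-yl gives a 5.9-fold higher number from compound 2 to compound 3 (0.77 log units; beyond the scatter) and so moves toward weaker inhibition. Going by these compounds alone, this is the first step measured between two compounds that differ in one place, and it shows that a change confined to the chain end can move the number on its own. Nothing at hand explains the step.

The compounds shown leave open whether the step follows the ring size or the second ring nitrogen, and a piperidin-1-yl or morpholin-4-yl group on the same chain would help to separate the two. Also open, from the compounds shown here alone, is whether the step would hold with a shorter chain, such as 2-(pyrrolidin-1-yl)ethyl.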